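A few compounds are considered here, and "the series" means these few. Any claim that something is new, unique, unknown or untested is made for them only; others in the source may bear on it.

Measured so far in a functional assay on RAW264.7 cells (Mus musculus) for inhibition, with a stated time of 4 days; a higher number here means a weaker inhibitor, a lower number a stronger inhibitor:
Compound 1 `COc1cc(/C=C/C(=O)c2cccc(-n3cc(C(C)(C)O)nn3)c2)ccc1O` gives 19800 nM.
Compound 2 `C=C(C)c1cn(-c2cccc(C(=O)/C=C/c3ccc(O)c(OC)c3)c2)nn1` gives 9790 nM.
Compound 3 `CCCCCc1ccc(-c2cn(-c3cccc(C(=O)/C=C/c4ccc(O)c(OC)c4)c3)nn2)cc1` gives 5780 nM.

Compound 3 has the lowest number of the three, but its gap to compound 2, a 1.7-fold lower number from compound 2 to compound 3 (0.23 log units; within the scatter), lies within the scatter, so no order between these two can be claimed; only against compound 1 does compound 3 stand clearly apart, a 3.4-fold lower number from compound 1 to compound 3 (0.53 log units; beyond the scatter).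

Compound 4 `COc1cc(/C=C/C(=O)c2cccc(-n3cc(-c4ccccc4C(F)(F)F)nn3)c2)ccc1O` differs from compound 3 in one place: 2-(trifluoromethyl)phenyl in place of 4-pentylphenyl on an aromatic carbon. For the measured compounds named here, no measured step exchanges one six-membered aromatic ring for another. The steps seen replace 1-hydroxy-1-methylethyl by 1-methylethenyl, a 2.0-fold lower number from compound 1 to compound 2 (0.31 log units; beyond the scatter), or by 4-pentylphenyl, a 3.4-fold lower number from compound 1 to compound 3 (0.53 log units; beyond the scatter), and the step from 1-methylethenyl to 4-pentylphenyl, a 1.7-fold lower number from compound 2 to compound 3 (0.23 log units; within the scatter), stays within the scatter. The group on this aromatic carbon has so far moved the numbers only modestly, so for compound 4 a step within or just beyond the scatter is expected in this assay, direction uncertain, leaning slightly toward a higher number. Compound 4 is therefore estimated at 7500 nM, with a range of 3000 nM to 18000 nM. The expected step is a 1.3-fold higher number from compound 3 to compound 4 (0.11 log units; within the scatter).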

Compound 4, half-maximal inhibitory concentration: 5070 nM
The estimate for compound 4 lay 1.5-fold (0.17 log units) above the measured number; low and high end bracket the measured number.
By their numbers in this assay, from the lowest: compounds 4, 3 and 2 (each within the scatter of the next); then compound 1.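

In this assay, for the compounds shown here, the first exchange of one phenyl-bearing group for another on this aromatic carbon, 2-(trifluoromethyl)phenyl in place of 4-pentylphenyl, gives no readable change, a 1.1-fold lower number from compound 3 to compound 4 (0.06 log units; within the scatter), even though the two groups carry different substituents. The new group also stays within the scatter against 1-methylethenyl, a 1.9-fold lower number from compound 2 to compound 4 (0.29 log units; within the scatter), and stands apart only from 1-hydroxy-1-methylethyl, a 3.9-fold lower number from compound 1 to compound 4 (0.59 log units; beyond the scatter), so compounds 2, 3 and 4 cannot be ordered and only compound 1 separates from them. No measured evidence is available to explain this pattern.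

It remains open whether an amine or a carboxylic acid on this aromatic carbon would move the number further than the groups shown. Also open, from the compounds shown here alone, is whether 4-(trifluoromethyl)phenyl would read like 2-(trifluoromethyl)phenyl.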